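This account rests on a few compounds, and the source may have more. Where it says the series, first, only, none or still open, it means among the compounds named here.

Measured in a physicochemical assay for lipophilicity; a higher number here means a more lipophilic compound, a lower number a more polar compound:
- Compound 1 `CCn1cnc2c(-c3ccc(F)c(Oc4cccc(S(=O)(=O)CC)c4)c3)cnnc21`: 2.3
- Compound 2 `CCn1cnc2c(-c3ccc(F)c(-c4cccc(C(=O)NC)c4)c3)cnnc21`: 2.8

Of these two, compound 2 has the higher number, at 2.8, and its gap to compound 1 lies beyond the scatter. Compound 3 `CCn1cnc2c(-c3ccc(F)c(-c4cc(C(=O)NC)ccc4F)c3)cnnc21` is compound 2 with one small change: fluoro in place of hydrogen on an aromatic carbon. It carries fluoro in place of hydrogen on an aromatic carbon, ortho to a large group and para to a methylcarbamoyl group. Compound 1 and compound 2 differ in more than one place, so neither value shows what this change does. A small rise in this assay that stays within the scatter is expected, estimated as a number 0.20 log units higher from compound 2 to compound 3 (within the scatter). Compound 3 is expected at 3, with an estimated range from 2.6 to 3.4.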

Compound 3, distribution coefficient: 3
Beside the measured number, compound 3's estimate shows no gap at the digits printed, within the range that was stated.
By their numbers in this assay, from the lowest: compound 1; then compounds 2 and 3 (each within the scatter of the next).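

Going by these compounds alone, compound 2 and compound 3 differ in this one place, so they give the first clean reading of fluoro in place of hydrogen on an aromatic carbon, ortho to a large group and para to a methylcarbamoyl group. In this assay the change reads a number 0.20 log units higher from compound 2 to compound 3 (within the scatter) and so cannot be told apart from repeat measurement. Nothing available explains this reading.

One swap on one carbon is all that is shown here. Going by these compounds, whether a chloro or methoxy group on that same carbon would move this assay beyond the scatter stays open, as does fluoro on the other carbons of this ring.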